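The compounds below may be only part of what the source reports. "The series", "measured", "known", "first", "only" and "open" are said of these compounds alone.

Measured in a functional assay on the whole organism with Rattus norvegicus as the target; on this read-out lower numbers stand for an effect already at smaller amounts and higher numbers for an effect only at larger amounts of compound:
- compound 1 `CCN(CCNC(=O)c1cc(Cl)c(N)cc1OC)Cc1ccoc1`: 3 mg/kg
- compound 2 `COc1cc(N)c(Cl)cc1C(=O)NCCN(C)C(C)c1ccccc1`: 1 mg/kg
- compound 3 `COc1cc(N)c(Cl)cc1C(=O)NCCN(C)CC1CCCCC1`: 3 mg/kg

In this assay compound 3 gives 3 mg/kg, the same number as compound 1, and these two share the highest value of the set. Compound 2 has a lower number, 1 mg/kg.

The next compound, compound 4 `COc1cc(N)c(Cl)cc1C(=O)NCCN(C)Cc1ccccc1C`, carries 2-methylphenyl in place of cyclohexyl on a saturated chain carbon bound to an amine nitrogen.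

Among the compounds with values here, only one measured step bears on this change: a 3.0-fold higher number from compound 2 to compound 3 (0.48 log units; beyond the scatter). There, cyclohexylmethyl replaced 1-phenylethyl on an amine nitrogen, so the compound with the aromatic ring held the lower number. This is a single, modest step, and the two groups are not the same as the one entering here. A shift of similar direction, but no larger, therefore seems reasonable. The expected change is a 2.0-fold lower number from compound 3 to compound 4 (0.30 log units; within the scatter), which may not clear the usual scatter by much. For compound 4 the estimated value is 1.5 mg/kg, with an expected range from 0.5 mg/kg to 4 mg/kg.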

Compound 4, dose for half-maximal effect: 2 mg/kg
Compound 4: middle estimate off by 1.3-fold (0.12 log units), on the low side; the range from low to high includes it.
By their numbers in this assay, from the lowest: compounds 2, 4, 1 and 3 (each within the scatter of the next, the first and the last beyond it).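

On the whole-animal read-out, this assay, replacing cyclohexyl with 2-methylphenyl on a saturated chain carbon bound to an amine nitrogen gives a 1.5-fold lower number from compound 3 to compound 4 (0.18 log units; within the scatter) and so does not separate the aromatic ring from the non-aromatic one. Comparing 2-methylbenzyl with 1-phenylethyl on the amine nitrogen gives a 2.0-fold higher number from compound 2 to compound 4 (0.30 log units; within the scatter) and so does not separate those two groups either, which places compound 4 within the scatter of both compounds that differ by a 3.0-fold higher number from compound 2 to compound 3 (0.48 log units; beyond the scatter) on either side of it. No measurement shown offers an explanation for these numbers.

The compounds shown do not separate the contribution of the ring from that of its methyl group, which plain benzyl on the same nitrogen could address. Going by these compounds, it also remains open whether a longer chain such as 2-phenylethyl would stay within this narrow range of doses.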